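The compounds below may be only part of what the source reports. "The series", "measured", "known", "first", "only" and "open" are said of these compounds alone.

Measured so far in a functional assay on Hep2C cells (Homo sapiens) for antiproliferative activity, read by MTT assay, with a stated time of 24 h; on this read-out lower numbers stand for stronger inhibition and higher numbers for weaker inhibition:
Compound 1, `Cc1ccc(-c2cc(-c3ccccc3)c3cc(Br)ccc3n2)cc1`, gives 175000 nM.
Compound 2, `Brc1ccc2nc(-c3ccco3)cc(-c3ccccc3)c2c1`, gives 102000 nM.
Compound 3, `COc1cc(-c2cc(-c3ccccc3)c3cc(Br)ccc3n2)cc(OC)c1OC`, gives "not determined" (no result reported), that is, no result is reported for it.

Compound 2 gives the lowest of the two numbers, but the gap to compound 1 is small: the step of a 1.7-fold lower number from compound 1 to compound 2 (0.23 log units; within the scatter) lies within the scatter of repeated measurements, so the two compounds cannot be told apart, and neither can be called more potent than the other.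

Compound 4, `N#Cc1ccc(-c2cc(-c3ccccc3)c3cc(Br)ccc3n2)cc1`, differs from compound 2 at a single place: 4-cyanophenyl in place of furan-2-yl on an aromatic carbon. Going by the values given here, only one measured step bears on this change, the one from compound 1 to compound 2, in which the group at that same place was exchanged from 4-methylphenyl to furan-2-yl; that exchange, a 1.7-fold lower number from compound 1 to compound 2 (0.23 log units; within the scatter), did not move the number beyond the scatter. Two different aromatic groups at this place thus gave close numbers, and 4-cyanophenyl is a further six-membered aromatic ring entering at the same place. Nothing in the measured data points to a shift beyond the scatter, so no step beyond the scatter is expected in this assay. Compound 4 is therefore estimated at 120000 nM, with a range from 40000 nM to 350000 nM, which means an expected step of a 1.2-fold higher number from compound 2 to compound 4 (0.07 log units; within the scatter).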

Compound 4, half-maximal inhibitory concentration: 98800 nM
Compound 4: the middle estimate sits 1.2-fold (0.08 log units) above what was measured, and the stated range covers the measured number.
By their numbers in this assay, from the lowest: compounds 4, 2 and 1 (each within the scatter of the next).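

In this assay, replacing the five-membered furan-2-yl with the six-membered, all-carbon 4-cyanophenyl gives a 1.0-fold lower number from compound 2 to compound 4 (0.01 log units; within the scatter), so this place next to the ring nitrogen accepts a change in ring size and ring atoms without a shift beyond the scatter. The second comparison adds something the first step could not show: with the same six-membered ring in place, exchanging only the small group on it gives a 1.8-fold lower number from compound 1 to compound 4 (0.25 log units; within the scatter), so a nitrile and a methyl on that ring cannot be told apart here. Three different aromatic groups at this place now give numbers within the scatter of one another, and no outside evidence is available to explain this result.

All of these groups are aromatic rings, so the compounds shown leave open whether a group without such a ring at this place, such as an amine, a carboxylic acid or a longer alkyl chain, would move the number beyond the scatter. They also say nothing about the bromine or the phenyl group elsewhere on the shared core, since both stay the same throughout.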